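The source may hold more compounds than are shown below. What is called first, only, known or untested is meant among the compounds shown, and "the series" means these compounds.

Measured compounds:
compound 1 `COc1cc(-n2ncnc2-c2cccc([N+](=O)[O-])c2)cc(OC)c1OC`; in a functional assay on Jurkat cells (Homo sapiens) for antiproliferative activity, read by MTT assay, with a stated time of 72 h (a higher number here means a weaker inhibitor, a lower number a stronger inhibitor), compound 1 gives > 10000 nM, a limit of the assay.
compound 2 `COc1ccccc1-c1ncnn1-c1cc(OC)c(OC)c(OC)c1`; in this assay compound 2 gives > 10000 nM, again a limit.
compound 3 `COc1cc(-n2ncnc2-c2ccc(C)cc2)cc(OC)c1OC`; in this assay compound 3 gives 300 nM.

For the measured compounds named here, compound 3 thus holds the only number in the set; the other two values sit at the limit of > 10000 nM in this assay, at which 2 of the 3 values shown sit. Going by the values given here, the one step, an at least 33-fold lower number from compound 2 to compound 3 (1.52 log units; beyond the scatter), is large, but it changes both the group and its place on the ring at once.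

Compound 4 `COc1ccc(-c2ncnn2-c2cc(OC)c(OC)c(OC)c2)cc1` differs from compound 3 by methoxy in place of methyl on an aromatic carbon. Among the compounds with values here, no measured step exchanges methyl for methoxy at the same place, so the step from compound 2 to compound 3 bears on it only indirectly. For compound 4 a step within the scatter is expected, a 1.5-fold lower number from compound 3 to compound 4 (0.18 log units; within the scatter), and its value in this assay is estimated at 200 nM, between 50 nM and 800 nM.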

Compound 4, half-maximal inhibitory concentration: 50 nM
Beside the measured number, compound 4's estimate is 4.0-fold (0.60 log units) above it; the range from low to high includes it.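

In this assay methoxy in place of methyl, para to a large group, gives a 6.0-fold lower number from compound 3 to compound 4 (0.78 log units; beyond the scatter) and so has a direct reading at this place. With the group held as methoxy, 4-methoxyphenyl in place of 2-methoxyphenyl gives an at least 200-fold lower number from compound 2 to compound 4 (2.30 log units; beyond the scatter) with only the place on the ring changed. The earlier step changed group and place together. Compound 2 stands at a limit, so this step is only a bound: the limit of > 10000 nM in this assay, at which 2 of the 4 values shown sit.

The compounds shown leave open how an ethoxy group, an amine or a chlorine at this same place compares with methoxy.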